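Replacing the aminopropyl side chain: compound 2 to compound 3

The compounds below may be only part of what the source reports. "The series", "measured", "known", "first", "only" and "open" are said of these compounds alone.

Within the data shown here, compound 2 `NCCCC[C@H](NC(=O)CN(c1nc(Cl)nc2[nH]cnc12)C1CC1)C(=O)OCc1ccccc1` holds the higher of the two numbers so far in a functional assay on the whole organism (Tail, strain ICR) with Mus musculus as the target, in the tail flick test, with a stated time of 60 min, at a dose of 25 umol/kg by the oral route; a higher number here means a stronger effect of the compound at the dose given, a lower number a weaker effect: compound 2 gives 41.2%, while compound 1 `O=C(OCc1ccccc1)[C@@H]1CCCN1C(=O)CN(c1nc(Cl)nc2[nH]cnc12)C1CC1` gives 34.4%, a gap within the usual scatter, so no order between the two is claimed. Compound 3 `CC(C)C[C@H](NC(=O)CN(c1nc(Cl)nc2[nH]cnc12)C1CC1)C(=O)OCc1ccccc1` differs from compound 2 by isopropyl in place of 3-aminopropyl on a saturated chain carbon, two bonds along the chain from an amide-type nitrogen and a carbonyl carbon. No measured step in the series covers this kind of change, so nothing shown bears on it directly. The step of a number 3.2 percentage points lower from compound 2 to compound 3 (within the scatter) is expected to stay within the scatter, with no clear direction. Compound 3 is estimated at 38%, with a range from 22% to 54%.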

Compound 3, a percentage reported as activity, at one dose (the size of the read-out at that dose, not a potency): 27.3%
The estimate for compound 3 lay 10.7 percentage points above the measured number; measured number inside the range.
By their numbers in this assay, from the lowest: compounds 3, 1 and 2 (each within the scatter of the next, the first and the last beyond it).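

In this assay, among these compounds, isopropyl in place of 3-aminopropyl gives a number 13.9 percentage points lower from compound 2 to compound 3 (beyond the scatter), the first step at this saturated chain carbon, showing that the number responds to a change in this side chain at the dose given. Among the compounds shown here, the entering group has no nitrogen, and the single step does not separate the loss of the amine from the change in chain shape. Nothing measured here accounts for the fall.

A plain butyl chain would test the amine apart from chain length. From the compounds shown here alone, whether a carboxylic acid or a longer aminoalkyl chain at this carbon keeps the number of compound 2 remains open.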